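The compounds below may be only part of what the source reports. "The series", "measured", "known", "first", "only" and "open" are said of these compounds alone.

Measured in a functional assay on HCT-116 cells (Homo sapiens) for inhibition, read by CCK-8 assay, with a stated time of 48 h (a higher number here means a weaker inhibitor, a lower number a stronger inhibitor), so far
compound 1 `COc1cc(-c2ccnc3cc(-c4ccc(C(F)(F)F)cc4)nn23)cc(OC)c1OC` gives 1860 nM
compound 2 `COc1cc(-c2ccnc3cc(-c4ccc5ccn(C)c5c4)nn23)cc(OC)c1OC` gives 1040 nM
compound 3 `COc1cc(-c2ccnc3cc(-c4ccc5cnn(C)c5c4)nn23)cc(OC)c1OC` gives 2440 nM

Among these three, compound 3 stands level with compound 1 through the step of a 1.3-fold higher number from compound 1 to compound 3 (0.12 log units; within the scatter) and apart from compound 2 through the step of a 2.3-fold higher number from compound 2 to compound 3 (0.37 log units; beyond the scatter) in the same read-out.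

Compound 4 `COc1ccc(-c2cc3nccc(-c4cc(OC)c(OC)c(OC)c4)n3n2)cc1F` differs from compound 3 by one exchange 3-fluoro-4-methoxyphenyl in place of 1-methyl-1H-indazol-6-yl on an aromatic carbon at the same aromatic carbon that varies across the measured compounds. For the measured compounds named here, no measured compound carries the 3-fluoro-4-methoxyphenyl group, so the estimate rests on the three steps at this carbon. Like the 4-(trifluoromethyl)phenyl of compound 1, the entering group has one six-membered aromatic ring of carbon only. The step of a 1.8-fold lower number from compound 1 to compound 2 (0.25 log units; within the scatter) stays within the scatter. Going by the values given here, only the step from the indole to the indazole passes the scatter, and modestly. These exchanges therefore give no ground for a large move in this assay and no firm direction. A slightly lower number than that of compound 3 is expected, with compound 1 at 1860 nM as the closest guide, and no step beyond the scatter is expected. The estimated step is a 1.4-fold lower number from compound 3 to compound 4 (0.16 log units; within the scatter) in this read-out. For compound 4 the estimated value is 1700 nM with an expected range from 700 nM to 4000 nM in this read-out.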

Compound 4, half-maximal inhibitory concentration: 2840 nM
Compound 4: the middle estimate sits 1.7-fold (0.22 log units) below what was measured; the range from low to high includes it.
By their numbers in this assay, from the lowest: compounds 2, 1, 3 and 4 (each within the scatter of the next, the first and the last beyond it).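

In this assay, the 3-fluoro-4-methoxyphenyl group, with one six-membered aromatic ring of carbon only, stands level with the two-ring 1-methyl-1H-indazol-6-yl, at a 1.2-fold higher number from compound 3 to compound 4 (0.07 log units; within the scatter), and also level with 4-(trifluoromethyl)phenyl, at a 1.5-fold higher number from compound 1 to compound 4 (0.18 log units; within the scatter). Among the four groups at this carbon, the only separation involving the new group is from 1-methyl-1H-indol-6-yl, at a 2.7-fold higher number from compound 2 to compound 4 (0.44 log units; beyond the scatter), and even that is modest, so the two single-ring groups do not separate from each other and ring count alone does not order these compounds, with the indole of compound 2 and the indazole of compound 3 as the pair of two-ring groups that do differ. No measured evidence on the compounds accounts for these differences.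

Still open, on these data alone, is whether a non-aromatic group at this carbon, such as a morpholine or another saturated amine, or a carboxylic acid, would move the number further than these aromatic groups do. Also open, as far as these compounds go, is how much the trimethoxyphenyl group shared by all four compounds contributes to the read-out in this assay.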